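Thiophen-2-yl Exchange in a Level Cytotoxicity Series

The source may hold more compounds than are shown below. What is called first, only, known or untested is meant among the compounds shown, and "the series" means these compounds.

Of the compounds shown here, three sharing one core have been measured in an ADME assay on NIH3T3 cells (Mus musculus) for cytotoxicity, read by MTT assay, with a stated time of 24 h; on this read-out lower numbers stand for stronger inhibition and higher numbers for weaker inhibition. There, compound 1 `O=C(CSc1nnc(-c2ccncc2)o1)N/N=C/c1ccc(Cl)cc1` gives 181000 nM, compound 2 `O=C(CSc1nnc(-c2ccncc2)o1)N/N=C/c1ccc([N+](=O)[O-])cc1` gives 195000 nM, and compound 3 `O=C(CSc1nnc(-c2ccncc2)o1)N/N=C/c1cc(Cl)cc(Cl)c1O` gives 171000 nM. Compound 3 therefore stands level with the other two, and the numbers set no order among them.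

Compound 4 `O=C(CSc1nnc(-c2ccncc2)o1)N/N=C/c1cccs1` keeps the shared core but carries thiophen-2-yl in place of 3,5-dichloro-2-hydroxyphenyl on a carbon with a double bond to nitrogen. Two measured exchanges at this same place bear on the change. One shows a 1.1-fold lower number from compound 1 to compound 3 (0.02 log units; within the scatter), and the other shows a 1.1-fold lower number from compound 2 to compound 3 (0.06 log units; within the scatter). A third exchange, on an aromatic carbon of the same group, shows a 1.1-fold higher number from compound 1 to compound 2 (0.03 log units; within the scatter). All three steps are small, yet none of them tests a five-membered aromatic ring, so the new group remains unmeasured in this series. On this limited evidence, no step beyond the scatter is expected in this assay, and no direction can be assigned with confidence. The estimate means a 1.1-fold higher number from compound 3 to compound 4 (0.02 log units; within the scatter), an expected step that stays within the scatter. The estimated value for compound 4 is 180000 nM, with an expected range from 110000 nM to 290000 nM.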

Compound 4, half-maximal inhibitory concentration: 189000 nM
Estimate against measurement, compound 4: 1.1-fold (0.02 log units) below, within the range that was stated.
By their numbers in this assay, from the lowest: compounds 3, 1, 4 and 2 (each within the scatter of the next).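

In this assay, going by these compounds alone, thiophen-2-yl brings a five-membered aromatic ring to this place for the first time, on a carbon with a double bond to nitrogen, and the read-out stays level with all three six-membered aromatic groups: replacing 3,5-dichloro-2-hydroxyphenyl gives a 1.1-fold higher number from compound 3 to compound 4 (0.04 log units; within the scatter), replacing 4-nitrophenyl gives a 1.0-fold lower number from compound 2 to compound 4 (0.01 log units; within the scatter), and replacing 4-chlorophenyl gives a 1.0-fold higher number from compound 1 to compound 4 (0.02 log units; within the scatter). The exchange from compound 3 also removes both chlorine atoms and the hydrogen-bond donor, replaces a carbon-only ring with one containing sulfur, and reduces the heavy-atom count of the group, yet the step stays within the scatter, so the four compounds remain level with no order among them. Nothing shown here accounts for this flat response.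

From the compounds shown here alone, every group at this place in the four compounds is an aromatic ring, so it remains open whether a cyclohexyl ring, a longer alkyl chain, an amine or a carboxylic acid there would stay level as well. The compounds also leave open whether the read-out would stay as flat with a change elsewhere on the shared core.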